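Compound 4: 2-oxopyrrolidin-1-yl in Place of Benzyl

The source may report more compounds than this note shows. Statements on the series, on what has been measured and on what is new or still open speak of the compounds shown alone.

Of the compounds shown here, three have so far been measured in an assay for inhibition of inositol hexakisphosphate kinase 3 (Homo sapiens), read by colorimetric assay, coupled enzyme assay and malachite green, with a stated time of 120 min, in the presence of a further agent that is not named here; a lower number here means a stronger inhibitor, a higher number a weaker inhibitor. Compound 1 `CNC(=O)/C=C/c1ccc2noc(-c3ccccc3)c2c1` gives 42600 nM, compound 2 `Cc1ccc(-c2onc3ccc(/C=C/C(=O)O)cc23)cc1` gives 11500 nM, and compound 3 `O=C(O)c1ccc2noc(-c3ccc(Cc4ccccc4)cc3)c2c1` gives 1290 nM. Compound 3 thus stands with the lowest number of the three; the gap to compound 2 lies beyond the scatter, and the gap to compound 1 is wider still. Going by the values given here, none of these three pairs differs in only one place, so no single-change step is available to calibrate the next move.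

Compound 4 `O=C(O)c1ccc2noc(-c3ccc(N4CCCC4=O)cc3)c2c1` is the next compound to be measured in this assay. It differs from compound 3 in one place: 2-oxopyrrolidin-1-yl in place of benzyl on an aromatic carbon. Among the compounds with values here, with no measured pair showing this kind of exchange, the size of the step is open. The expected step, a 1.9-fold higher number from compound 3 to compound 4 (0.29 log units; within the scatter), is a modest move toward a higher number, at the edge of the scatter. Compound 4 is accordingly estimated at 2500 nM in this assay, with a range from 800 nM to 8000 nM, anchored on compound 3 because it gives 1290 nM.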

Compound 4, half-maximal inhibitory concentration: 2170 nM
Beside the measured number, compound 4's estimate is 1.2-fold (0.06 log units) above it, within the range that was stated.
By their numbers in this assay, from the lowest: compounds 3 and 4 (each within the scatter of the next); then compound 2; then compound 1.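

In this assay, putting 2-oxopyrrolidin-1-yl in place of benzyl on this aromatic carbon gives a 1.7-fold higher number from compound 3 to compound 4 (0.23 log units; within the scatter), so the exchange leaves the two compounds within the scatter of each other. Going by these compounds alone, this is the first step that can be read at a single place, and it shows that this position accepts two quite different groups with no measurable separation: one with a six-membered aromatic ring of carbon only and no hydrogen-bond acceptor, the other with a five-membered non-aromatic ring and a hydrogen-bond acceptor. Nothing available accounts for this likeness.

The compounds shown leave open whether a much smaller group at this place, such as an amine or a methoxy group, would read the same. They also leave open what an ester in place of the carboxylic acid would do.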